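From Ethoxy to Methoxy on a Shared Core

This account rests on a few compounds, and the source may have more. Where it says the series, first, only, none or still open, it means among the compounds named here.

Compound 1 `CCO/C(O)=C1\C(C)=NC(C)=C([N+](=O)[O-])C1c1ccncc1` carries an ethoxy group and a pyridin-4-yl ring on a saturated ring carbon. In a functional assay (cardiac atrium) for agonist activity, with Cavia porcellus as the target (a higher number here means that more compound is needed for the effect, a lower number that less compound is needed), compound 1 gives 6460 nM. Compound 2 `CO/C(O)=C1\C(C)=NC(C)=C([N+](=O)[O-])C1c1ccncc1` differs from it only by hydrogen in place of methyl on a saturated chain carbon bound to an oxygen on an unsaturated carbon, a change that brings a 7.5-fold higher number from compound 1 to compound 2 (0.88 log units; beyond the scatter), so that compound 2 gives 48500 nM. Compound 3 `CCO/C(O)=C1\C(C)=NC(C)=C([N+](=O)[O-])C1c1cccnc1` keeps the ethoxy group, but its core differs from the core of compound 1 by pyridin-3-yl in place of pyridin-4-yl on a saturated ring carbon; this brings a 1.4-fold higher number from compound 1 to compound 3 (0.14 log units; within the scatter), and compound 3 gives 8840 nM. Compound 4 `CO/C(O)=C1\C(C)=NC(C)=C([N+](=O)[O-])C1c1cccnc1` has not yet been measured. It differs from compound 3 by hydrogen in place of methyl on a saturated chain carbon bound to an oxygen on an unsaturated carbon, the same change that separates compound 1 from compound 2, made at the same place. For the measured compounds named here, because the only example of this change so far is a 7.5-fold higher number from compound 1 to compound 2 (0.88 log units; beyond the scatter), a step of about that size is expected here as well, a 7.0-fold higher number from compound 3 to compound 4 (0.85 log units; beyond the scatter). Compound 4 is therefore estimated to give 62000 nM in this assay, with a likely range from 25000 nM to 150000 nM. Whether the number lands there will be settled once the result is known.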

Compound 4, half-maximal effective concentration: 70000 nM
The estimate for compound 4 lay 1.1-fold (0.05 log units) below the measured number; the measured number falls inside the stated range.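

With pyridin-3-yl on the saturated ring carbon, going from ethoxy to methoxy gives a 7.9-fold higher number from compound 3 to compound 4 (0.90 log units; beyond the scatter) in this assay, and this step matches the one seen with pyridin-4-yl: the same change on two cores in this assay, a 7.5-fold higher number (0.88 log units; beyond the scatter) from compound 1 to compound 2 and a 7.9-fold higher number (0.90 log units; beyond the scatter) from compound 3 to compound 4, 1.1-fold (0.02 log units) apart, within the scatter of two such steps. The ring change, read among the methoxy compounds, gives a 1.4-fold higher number from compound 2 to compound 4 (0.16 log units; within the scatter), which also matches its counterpart among the ethoxy compounds: the same change on two cores in this assay, a 1.4-fold higher number (0.14 log units; within the scatter) from compound 1 to compound 3 and a 1.4-fold higher number (0.16 log units; within the scatter) from compound 2 to compound 4, 1.1-fold (0.02 log units) apart, within the scatter of two such steps. Across these four compounds, each change therefore carries over from one core to the other with its size intact, but this rests on a single pair of steps per change in one assay, so it does not show that the same would hold on other cores, and it does not explain why the steps have these sizes.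

From the compounds shown here alone, only ethoxy and methoxy appear at the oxygen, so it remains open whether a longer chain such as propoxy would continue the trend seen on shortening ethoxy to methoxy. For the compounds shown here, only two pyridine rings appear on the saturated ring carbon, so a phenyl ring there is also an open case.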